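The compounds below may be only part of what the source reports. "The series", "measured", "known", "first", "only" and "open" are said of these compounds alone.

Three compounds have been measured in a functional assay on HepG2 cells (Homo sapiens) for antiproliferative activity, read by MTT assay; a higher number here means a weaker inhibitor, a lower number a stronger inhibitor:
compound 1 `O=C1N=C(N2CCC[C@H]2C(=O)Nc2ccc3ncnc(Nc4cccc(Cl)c4)c3c2)S/C1=C/c1cccc(Cl)c1` gives 27600 nM;
compound 2 `O=C1N=C(N2CCC[C@H]2C(=O)Nc2ccc3ncnc(Nc4cccc(Cl)c4)c3c2)S/C1=C/c1ccccc1Cl` gives 28100 nM;
compound 3 `O=C1N=C(N2CCC[C@H]2C(=O)Nc2ccc3ncnc(Nc4cccc(Cl)c4)c3c2)S/C1=C/c1ccc(-c2ccccc2)cc1` gives 15400 nM.

Among these three numbers compound 1 holds the second highest. Its nearest neighbour is compound 2, with a 1.0-fold higher number from compound 1 to compound 2 (0.01 log units; within the scatter), a step within the scatter; its furthest is compound 3, with a 1.8-fold lower number from compound 1 to compound 3 (0.25 log units; within the scatter), also within the scatter. The remaining pair shows a 1.8-fold lower number from compound 2 to compound 3 (0.26 log units; within the scatter), again within the scatter, so all three sit within the usual spread of one another.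

Compound 4 `O=C1N=C(N2CCC[C@H]2C(=O)Nc2ccc3ncnc(Nc4cccc(Cl)c4)c3c2)S/C1=C/c1ccccc1Br` has not yet been measured. It differs from compound 1 in one place: 2-bromophenyl in place of 3-chlorophenyl on a double-bonded chain carbon bound to a double-bonded ring carbon. The measured step bearing most directly on this change replaced the same 3-chlorophenyl with 2-chlorophenyl at the same place and gave a 1.0-fold higher number from compound 1 to compound 2 (0.01 log units; within the scatter). A 2-bromophenyl at that place is the closest analogue of that move, and the change to 4-phenylphenyl likewise stayed within the scatter, a 1.8-fold lower number from compound 1 to compound 3 (0.25 log units; within the scatter). No shift beyond the scatter is therefore expected in this assay. For compound 4 the estimated step is a 1.0-fold lower number from compound 1 to compound 4 (0.01 log units; within the scatter). Compound 4 is expected to give 27000 nM, with a range from 13000 nM to 56000 nM.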

Compound 4, half-maximal inhibitory concentration: 24300 nM
Compound 4: the middle estimate sits 1.1-fold (0.05 log units) above what was measured; the range from low to high includes it.
By their numbers in this assay, from the lowest: compounds 3, 4, 1 and 2 (each within the scatter of the next).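

In this assay, the halogen alone can now be read at this place: bromo in place of chloro on an aromatic carbon gives a 1.2-fold lower number from compound 2 to compound 4 (0.06 log units; within the scatter) and no shift beyond the scatter. Changing both the halogen and the ring pattern, from 3-chlorophenyl to 2-bromophenyl, gives a 1.1-fold lower number from compound 1 to compound 4 (0.06 log units; within the scatter) and also stays within the scatter, as does the switch from 4-phenylphenyl to 2-bromophenyl, with a 1.6-fold higher number from compound 3 to compound 4 (0.20 log units; within the scatter) as its step. So compounds 1 to 4 all sit within the scatter of one another, and nothing measured here speaks to why these numbers stay so close.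

Going by these compounds, the groups at this place are all phenyl rings carrying a halogen or a further phenyl, so the effect of an amine or a carboxylic acid there remains open. Also open, on these data alone, is whether a change elsewhere on the shared core would move the number beyond the scatter.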